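Replacing the Acid of Compound 2 with a Sulfonamide

The source may report more compounds than this note shows. Statements on the series, on what has been measured and on what is new or still open speak of the compounds shown alone.

Two measured compounds anchor this account. Compound 1 `CCc1c(COc2ccc(C(=O)CC(C)(C)CC(=O)O)cc2)ccc(C(C)=O)c1O` was tested in a functional assay on ileum (Cavia porcellus) with cysteinyl leukotriene receptor (Homo sapiens) as the target (on this read-out lower numbers stand for lower potency and higher numbers for higher potency (the scale is a negative logarithm)), and compound 1 gives 7.46; 7.6 (2 entries), as summarized in the several entries of compound 1 in this assay, 7.46; 7.6 (2 entries). Compound 2 `CCCc1c(COc2ccc3c(c2)CCC(CC(=O)O)C3=O)ccc(C(C)=O)c1O` shares the substituted phenol portion of compound 1, and in this assay compound 2 gives 7.71. For the measured compounds named here, this is the only number recorded for compound 2, alongside one further entry that carries no single number, and it sits within the usual scatter of the readings for compound 1. Going by the values given here, no two measured compounds differ in a single place, so no measured step is available to guide what follows.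

Compound 3 `CCCc1c(COc2ccc3c(c2)CCC(CC(=O)NS(=O)(=O)c2ccccc2C)C3=O)ccc(C(C)=O)c1O` has not yet been measured. It differs from compound 2 in one place: ((2-methylphenyl)sulfonyl)amino in place of hydroxy on a carbonyl carbon. Among the compounds with values here, with no measured step to lean on, the expectation starts from the value of compound 2 alone. The expected step is a number 0.49 log units higher from compound 2 to compound 3 (beyond the scatter), a modest rise in this assay that goes somewhat beyond the scatter, though with wide uncertainty. Compound 3 is accordingly estimated at 8.2, with a range from 7.5 to 8.9.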

Compound 3, negative logarithm of the antagonist equilibrium constant: 7.93
Compound 3: middle estimate off by 0.27 log units, on the high side, and the stated range covers the measured number.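

In this assay, for the compounds shown here, putting ((2-methylphenyl)sulfonyl)amino in place of hydroxy on a carbonyl carbon gives the first step that can be read in this account: a number 0.22 log units higher from compound 2 to compound 3 (within the scatter). Going by these compounds alone, the two compounds therefore cannot be told apart on this read-out, which the earlier compounds could not show, since no two of them differed in a single place. For this core, the carboxylic acid of compound 2 is not needed to hold the read-out at this level, and the position on the carbonyl carbon accepts a far larger group carrying a six-membered aromatic ring; entries for one compound in this assay also differ among themselves, as seen in the readings for compound 1: the several entries of compound 1 in this assay, 7.46; 7.6 (2 entries)

The compounds shown leave open whether the methyl on the aromatic ring matters, as they do not say how a phenylsulfonylamino group without it, a methylsulfonylamino group or a tetrazole would read in this assay. They also leave open whether the same exchange at the carboxylic acid of compound 1 would give a similar step.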